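The source may hold more compounds than are shown below. What is called first, only, known or untested is meant among the compounds shown, and "the series" means these compounds.

Among the two compounds measured so far, compound 2 `COc1ccc(CNC(=O)c2cc(Oc3ccc(/C=C/c4ccccn4)cc3)ccn2)cc1` gives the highest number: in a functional assay on A549 cells (Homo sapiens) for antiproliferative activity, read by CCK-8 assay, with a stated time of 48 h (on this read-out lower numbers stand for stronger inhibition and higher numbers for weaker inhibition), compound 2 gives 63600 nM. Its nearest neighbour is compound 1 `COc1ccc(NC(=O)c2cc(Oc3ccc(/C=C/c4ccccn4)cc3)ccn2)cc1`, which in this assay gives 20000 nM. Within the data shown here, the only measured step, a 3.2-fold higher number from compound 1 to compound 2 (0.50 log units; beyond the scatter), shows that exchanging the group on the amide-type nitrogen can move the read-out beyond the usual scatter. Compound 3 `O=C(c1cc(Oc2ccc(/C=C/c3ccccn3)cc2)ccn1)N1CCCC1` has not yet been tested; it differs from compound 2 by pyrrolidin-1-yl in place of (4-methoxybenzyl)amino on a carbonyl carbon. Among the measured compounds shown here, no measured pair puts a five-membered non-aromatic ring in place of an amino group on the carbonyl carbon, so the single known step is only a loose guide, and a modest shift in either direction remains plausible. Compound 3 is therefore expected to show a step of a 1.1-fold lower number from compound 2 to compound 3 (0.03 log units; within the scatter). Compound 3 is estimated at 60000 nM, with a range from 15000 nM to 200000 nM.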

Compound 3, half-maximal inhibitory concentration: 15600 nM
Compound 3: middle estimate off by 3.8-fold (0.59 log units), on the high side; measured number inside the range.
By their numbers in this assay, from the lowest: compounds 3 and 1 (each within the scatter of the next); then compound 2.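

The change to pyrrolidin-1-yl on the carbonyl carbon brings a 4.1-fold lower number from compound 2 to compound 3 (0.61 log units; beyond the scatter) in this assay, so this place accepts a small non-aromatic ring with no hydrogen-bond donor and no six-membered aromatic ring. Set against the (4-methoxyphenyl)amino group, the same ring gives a 1.3-fold lower number from compound 1 to compound 3 (0.11 log units; within the scatter), so an aromatic group on an amide nitrogen is not needed here to reach the activity of compound 1. Nothing measured here explains why these changes act as they do.

In the step to compound 3, the amide hydrogen and the aromatic ring leave together, so their separate contributions remain unresolved. Also open, from the compounds shown here alone, is how piperidine, morpholine or a simple dimethylamino group would read out on the same carbonyl carbon.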